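Working notes on a covalent B-cell antiproliferative series

The source may report more compounds than this note shows. Statements on the series, on what has been measured and on what is new or still open speak of the compounds shown alone.

Measured so far:
- compound 1 `C=CC(=O)Nc1cccc(-n2c(=O)n(C)c3cnc(Nc4ccc(OCCOC)cc4)nc32)c1`: 6.84 nM
- compound 2 `C=CC(=O)Nc1cccc(-n2c(=O)n(CC3CC3)c3cnc(Nc4ccc(N(C)C)nc4)nc32)c1`: 818 nM
- compound 3 `C=CC(=O)Nc1cccc(Nc2nc(Nc3ccc(OCCOC)cc3)ncc2SC)c1`: 30.6 nM

In a functional assay on cells (B-cell) for antiproliferative activity (on this read-out lower numbers stand for stronger inhibition and higher numbers for weaker inhibition), compound 3 gives the second highest of the three numbers. Compound 1 sits lower by a gap beyond the scatter, and compound 2 lies far higher, also beyond the scatter. Compound 4 `C=CC(=O)Nc1cccc(Nc2nc(Nc3ccc(OCCOC)cc3)ncc2[S+](C)[O-])c1` differs from compound 3 by a group of 3 heavy atoms (1 carbon, 1 oxygen, 1 sulfur; no ring) in place of a group of 2 heavy atoms (1 carbon, 1 sulfur; no ring), on an aromatic carbon. Going by the values given here, no measured pair shows this change, so no step can be read from the data for it. The expected step in this assay is a 2.0-fold higher number from compound 3 to compound 4 (0.29 log units; within the scatter), a small move toward weaker inhibition that may not exceed the scatter. Compound 4 is estimated at 60 nM, with a range from 15 nM to 250 nM.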

Compound 4, half-maximal inhibitory concentration: 5.85 nM
The estimate for compound 4 lay 10-fold (1.01 log units) above the measured number; the whole stated range lies above it.
By their numbers in this assay, from the lowest: compounds 4 and 1 (each within the scatter of the next); then compound 3; then compound 2.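

In this assay, replacing methylsulfanyl with the group of 3 heavy atoms on this aromatic carbon gives a 5.2-fold lower number from compound 3 to compound 4 (0.72 log units; beyond the scatter), so the position takes the larger group with a gain rather than a loss. Going by these compounds alone, this is the first step read at this position, as the earlier compounds offered no matched pair. No data at hand explain the step.

From the compounds shown here alone, whether an amine, a carboxylic acid or a longer chain on this aromatic carbon would move the number in the same direction remains open. So does whether the step carries over to the other cores in the series.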